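Methylamino Link Gives Way to a Methylene Link

A few compounds are considered here, and "the series" means these few. Any claim that something is new, unique, unknown or untested is made for them only; others in the source may bear on it.

Among the compounds with values here, compound 2 `CN(c1cccnc1)c1cc(F)cc(-n2nnc(-c3ccccn3)n2)c1` holds the lowest of the two numbers so far in a functional assay for antagonist activity at metabotropic glutamate receptor 5 (Homo sapiens); a higher number here means a weaker inhibitor, a lower number a stronger inhibitor: compound 2 gives 22 nM. Compound 1 `c1ccc(-c2nnn(-c3ccc(Oc4cccnc4)cc3)n2)nc1`, built on a different core, gives 737 nM in this assay, a gap well beyond the usual scatter. Within the data shown here, compound 3 `Fc1cc(Cc2cccnc2)cc(-n2nnc(-c3ccccn3)n2)c1` keeps the core of compound 2 and changes only one group: (pyridin-3-yl)methyl in place of methyl(pyridin-3-yl)amino on an aromatic carbon. Among the measured compounds shown here, no measured pair shows this exchange, so the expectation rests on compound 2 alone. A modest weakening is expected, a 3.6-fold higher number from compound 2 to compound 3 (0.56 log units; beyond the scatter), because compound 2 stands at 22 nM. Compound 3 is expected to give 80 nM in this assay, within a range from 20 nM to 400 nM.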

Compound 3, half-maximal inhibitory concentration: 17 nM
Compound 3: the middle estimate sits 4.7-fold (0.67 log units) above what was measured; measured number below the stated range.
By their numbers in this assay, from the lowest: compounds 3 and 2 (each within the scatter of the next); then compound 1.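

Exchanging methyl(pyridin-3-yl)amino for (pyridin-3-yl)methyl gives a 1.3-fold lower number from compound 2 to compound 3 (0.11 log units; within the scatter) in this assay and leaves the two compounds indistinguishable. At this position, then, the pyridin-3-yl ring can be attached through a plain carbon link, with no amino nitrogen or its methyl group needed to keep the number at this level. No measurement offered here explains why the exchange is tolerated.

Still open, going by these compounds, is whether an oxygen link, a carbonyl link or a longer chain such as ethylene would serve equally well at this position.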